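This account rests on a few compounds, and the source may have more. Where it says the series, first, only, none or still open, it means among the compounds named here.

Measured compounds:

Compound 1, `COc1ccc(C2CC2C(=O)NNc2nncc3ccccc23)cc1`, gives 64000 nM in a functional assay on PC-3 cells (Homo sapiens) for inhibition, read by MTT assay, with a stated time of 72 h; a higher number here means a weaker inhibitor, a lower number a stronger inhibitor.
Compound 2, `O=C(NNc1nncc2ccccc12)C1CC1c1ccc(OCC(F)(F)F)cc1`, gives 67000 nM in this assay.
Compound 3, `O=C(NNC(=O)C1CC1c1ccc(OCC(F)(F)F)cc1)c1ccncc1`, gives 44000 nM in this assay.

All three numbers lie within the scatter of one another, so none of these compounds can be set apart from the others on this evidence.

Compound 2 and compound 1 differ in one place only: hydrogen in place of trifluoromethyl on a saturated chain carbon bound to an oxygen on an aromatic ring. This change gave a 1.0-fold lower number from compound 2 to compound 1 (0.02 log units; within the scatter).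

Compound 4, `COc1ccc(C2CC2C(=O)NNC(=O)c2ccncc2)cc1`, has not yet been measured. It relates to compound 3 in the same way: hydrogen in place of trifluoromethyl on a saturated chain carbon bound to an oxygen on an aromatic ring. The place of the change is described in the same words in both pairs, so this is the same change made a second time, on a different core. How the core of compound 3 differs from the core of compound 2 is not broken down here.

The expectation for compound 4 rests on one comparison. The step is expected to be no change at the digits printed from compound 3 to compound 4 (within the scatter), because in compound 2 and compound 1 the same change gave a 1.0-fold lower number from compound 2 to compound 1 (0.02 log units; within the scatter), a step within the scatter. Compound 4 is therefore expected to give about 44000 nM in this assay, most likely between 20000 nM and 95000 nM. For the measured compounds named here, only two compounds support this reading, so a larger surprise on the different core cannot be ruled out.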

Compound 4, half-maximal inhibitory concentration: > 100000 nM
Compound 4: a limit, no number; the forecaster's own chance of this, stated with the estimate: 15%; at least 2.2-fold (0.35 log units) between middle value and limit.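

In this assay compound 4 gives > 100000 nM, which is a limit of the assay and not a number. Replacing 2,2,2-trifluoroethoxy with methoxy on the core of compound 3 gave an at least 2.2-fold higher number from compound 3 to compound 4 (0.35 log units; beyond the scatter), so on this core the change left a mark that can be read beyond the scatter, whereas on the core of compound 2 the same change left none. This does not show that the change truly acts differently on the two cores, nor does it show that a result on one core can be carried over to the other, and this pair gives only a lower bound on the size of the step, so the comparison stays unsettled: the same change on two cores in this assay, a 1.0-fold lower number (0.02 log units; within the scatter) from compound 2 to compound 1 and an at least 2.2-fold higher number (0.35 log units; beyond the scatter) from compound 3 to compound 4; the limit leaves it open whether they differ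

The compounds shown leave open how other groups in this place would read on either core, for example an ethoxy group, a longer chain ending in an amine, or a plain hydroxyl on the aromatic ring in place of the ether. They also leave open whether the same swap of 2,2,2-trifluoroethyl to methyl would follow either pattern on a third core, such as one carrying a carboxylic acid.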